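The source may report more compounds than this note shows. Statements on the series, on what has been measured and on what is new or still open speak of the compounds shown alone.

Measured in a toxicity assay on NIH3T3 cells (Mus musculus) for cytotoxicity, read by resazurin assay; a lower number here means that less compound is needed, a higher number that more compound is needed for the effect:
- compound 1 `c1ccc(-c2ccc(Cn3cncc3CNc3cccc(-c4ccccc4)c3)cc2)cc1`: 10000 nM
- compound 2 `COC(=O)c1ccc(NCc2cncn2Cc2cccc(C)c2)cc1-c1ccccc1`: > 10000 nM, which is a limit of the assay and not a number
- compound 3 `O=[N+]([O-])c1ccc(Cn2cncc2CNc2cccc(-c3ccccc3)c2)cc1`: 10000 nM

Compound 1 stands level with compound 3 at the digits shown, and the one measured step, no change at the digits printed from compound 1 to compound 3 (within the scatter), lies within the scatter. Among the measured compounds shown here, for compound 2 the assay gives only (the limit of > 10000 nM in this assay, at which 1 of the 3 values shown sits), so no step to compound 2 can be sized.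

Compound 4 `c1ccc(-c2ccc(Cn3cncc3CNc3ccc(N4CCCC4)c(-c4ccccc4)c3)cc2)cc1` is compound 1 with pyrrolidin-1-yl in place of hydrogen on an aromatic carbon. For the measured compounds named here, no measured step adds a pyrrolidin-1-yl or touches the aromatic carbon on which it enters; the only step available, from compound 1 to compound 3, exchanges a group elsewhere and gave no change beyond the scatter. The series therefore offers no measured ground for a directional step in this assay on going from compound 1 to compound 4, and none beyond the scatter is expected; a value reported only as a limit remains possible, as it was for compound 2.

Compound 4 is expected at 10000 nM, within 5000 nM to 20000 nM, so that no change at the digits printed from compound 1 to compound 4 (within the scatter) is estimated to be no change beyond the scatter.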

Compound 4, half-maximal effective concentration: > 1000 nM
Compound 4 gave a limit, no number; the forecaster's own chance of this, stated with the estimate: 40%; the middle value does not contradict the limit.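

In this assay compound 4 gives > 1000 nM, which is a limit of the assay and not a number. Among the compounds shown here, the step between compound 1 and compound 4 therefore cannot be read, and no new step follows from this result. The compounds shown leave open whether pyrrolidin-1-yl in place of hydrogen on an aromatic carbon shifts the half-maximal effective concentration at all, and in which direction.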